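The source may report more compounds than this note shows. Statements on the series, on what has been measured and on what is new or still open speak of the compounds shown alone.

Working notes on the series.

Of the compounds shown here, two of the shared core have been measured in an in vitro assay on Sf21 cells for inhibition of high affinity 3',5'-cyclic-AMP phosphodiesterase 7A (Homo sapiens), read by scintillation proximity assay, with a stated time of 30 min; a lower number here means a stronger inhibitor, a higher number a weaker inhibitor. Compound 1 `CSc1ccc(NC(=O)c2cn(Cc3c(F)cccc3F)c3ccc(=O)[nH]c3c2=O)cc1` gives 86 nM in this assay. Compound 2 `COc1cc(NC(=O)c2cn(Cc3ccccc3Br)c3ccc(=O)[nH]c3c2=O)cc(OC)c1OC` is reported in this assay only as a limit, > 1000 nM, so no number stands for it. Going by the values given here, the two differ in more than one place, and the pair shows only that compound 1 sits at a measured value while compound 2 sits at the limit of this assay (the limit of > 1000 nM in this assay, at which 1 of the 2 values shown sits).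

The next compound, compound 3 `COc1cc(NC(=O)c2cn(Cc3ccc(F)cc3)c3ccc(=O)[nH]c3c2=O)cc(OC)c1OC`, keeps the anilide part of compound 2 and changes the group on the saturated chain carbon bound to an aromatic nitrogen: 4-fluorophenyl in place of 2-bromophenyl on a saturated chain carbon bound to an aromatic nitrogen, that is, 2-bromobenzyl becomes 4-fluorobenzyl.

With compound 2 known only as a limit, the size of this step cannot be anchored. The expected change in this assay is small, within the scatter, and the estimate for the step that the limit leaves unreadable from compound 2 to compound 3 is given with little confidence. Compound 3 is expected near 1200 nM in this assay, with a range from 300 nM to 5000 nM.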

Compound 3, half-maximal inhibitory concentration: 868 nM
Beside the measured number, compound 3's estimate is 1.4-fold (0.14 log units) above it; low and high end bracket the measured number.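

In this assay, going by these compounds alone, compound 3 gives 868 nM, the first measured number for the anilide part it shares with compound 2. The exchange of 2-bromophenyl for 4-fluorophenyl on a saturated chain carbon bound to an aromatic nitrogen amounts to an at least 1.1-fold lower number from compound 2 to compound 3 (0.06 log units; that floor lies within the scatter), so a real change at this position is neither shown nor excluded. On these data alone, the upper size of the step stays unknown because compound 2 is held only as a limit: the limit of > 1000 nM in this assay, at which 1 of the 3 values shown sits.

Still open, as far as these compounds go, is how a 4-bromobenzyl or a 2-fluorobenzyl group would read on the same anilide part, which would separate the identity of the halogen from its place on the ring, and whether an unsubstituted benzyl group would read differently from either halogenated one. Compound 1 differs from compound 3 in more than one place, so the compounds shown do not tell how much of the gap between their values belongs to the anilide part and how much to the benzyl group.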